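This account rests on a few compounds, and the source may have more. Where it says the series, first, only, none or still open, it means among the compounds named here.

Compound 2, `COC[C@H](C(C)C)C(c1ccc(O)c(OC)c1)c1ccc(O)c(OC)c1`, carries two aryl groups and a 1-(methoxymethyl)-2-methylpropyl group on the saturated chain carbon between them. Within the data shown here, in a functional assay on HL-60 cells (Homo sapiens) for cytotoxicity, read by WST assay, with a stated time of 48 h (a lower number here means a stronger inhibitor, a higher number a weaker inhibitor), compound 2 gives 72000 nM, the highest of the two numbers measured so far, though its nearest neighbour, compound 3, `COc1cc(C(c2ccc(O)c(OC)c2)[C@H](C)[C@H](C)CF)ccc1O`, lies within the scatter: in this assay compound 3 gives 56000 nM. Compound 1, `COc1cc(C(c2ccc(O)c(OC)c2)[C@@H](C)[C@@H](C)CO)ccc1O`, reaches only a limit of this assay, > 100000 nM (the limit of > 100000 nM in this assay, at which 1 of the 3 values shown sits); the step of an at least 1.3-fold lower number from compound 1 to compound 2 (0.14 log units; that floor lies within the scatter) and the step of an at least 1.7-fold lower number from compound 1 to compound 3 (0.25 log units; that floor lies within the scatter) are therefore floors that lie within the scatter.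

Compound 4 is `COc1cc(C(c2ccc(O)c(OC)c2)[C@@H](CF)C(C)C)ccc1O`. It differs from compound 2 as follows: 1-(fluoromethyl)-2-methylpropyl in place of 1-(methoxymethyl)-2-methylpropyl on a saturated chain carbon bound to two aromatic carbons. The closest measured step is a 1.3-fold lower number from compound 2 to compound 3 (0.11 log units; within the scatter), which also replaces the methoxymethyl-bearing chain by a fluoromethyl-bearing one and lies within the scatter. Among the measured compounds shown here, nothing among the measured steps exceeds the scatter, so no step beyond it is expected from compound 2 to compound 4 either; the step of a 1.2-fold lower number from compound 2 to compound 4 (0.08 log units; within the scatter) is what the estimate means. For compound 4 a value of 60000 nM is estimated in this assay, with a range of 25000 nM to 150000 nM, and a fair chance that only a limit is reported.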

Compound 4, half-maximal inhibitory concentration: 39000 nM
Compound 4: middle estimate off by 1.5-fold (0.19 log units), on the high side, within the range that was stated.
By their numbers in this assay, from the lowest: compounds 4, 3 and 2 (each within the scatter of the next). At a limit, above all of these: compound 1.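

In this assay the step of an at least 2.5-fold lower number from compound 1 to compound 4 (0.40 log units; beyond the scatter) is the first in this set to clear the scatter, and it is only a floor because compound 1 stands at a limit: the limit of > 100000 nM in this assay, at which 1 of the 4 values shown sits.

The other two new steps, a 1.8-fold lower number from compound 2 to compound 4 (0.27 log units; within the scatter) and a 1.4-fold lower number from compound 3 to compound 4 (0.16 log units; within the scatter), stay within the scatter, so on a saturated chain carbon bound to two aromatic carbons, 1-(fluoromethyl)-2-methylpropyl cannot be told apart from either 1-(methoxymethyl)-2-methylpropyl or 2-(fluoromethyl)-1-methylpropyl. Compound 4 alone is thus separated from the 2-(hydroxymethyl)-1-methylpropyl compound, while the floors for compound 2 and compound 3 lie within the scatter, and those two compounds therefore do not share that separation.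

From the compounds shown here alone, how far compound 1 truly lies from the other three remains open, as its number is a limit and not a measured value. Also open, going by these compounds, is whether an amine, a carboxylic acid or a longer chain at this place would give a step beyond the scatter from compound 4.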